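Para substituent change in a pyridine carboxamide series: acetamido variant

The source may report more compounds than this note shows. Statements on the series, on what has been measured and on what is new or still open speak of the compounds shown alone.

Compound 1 `COc1cc(C(=O)Nc2nn[nH]n2)nc(-c2ccc(Cl)cc2)c1` gives 0% in a functional assay on the whole organism with Rattus norvegicus as the target, at a dose of 1 mg/kg by the oral route; on this read-out higher numbers stand for a stronger effect at the one dose given and lower numbers for a weaker effect. Compound 2 `COc1cc(C(=O)Nc2nn[nH]n2)nc(-c2ccc(N(C)C)cc2)c1` gives 64% in this assay.

Compound 2 stands highest of the two numbers; the nearest is compound 1, with a number 64 percentage points higher from compound 1 to compound 2 (beyond the scatter). Compound 3 `COc1cc(C(=O)Nc2nn[nH]n2)nc(-c2ccc(NC(C)=O)cc2)c1` differs from compound 2 by acetamido in place of dimethylamino on an aromatic carbon. Among the measured compounds shown here, no measured step covers this exact change; only the step from compound 1 to compound 2 concerns the same position, and it was large, so the group at that place evidently matters in this assay. Going by these compounds, whether acetamido behaves like dimethylamino is unknown. A moderate drop is expected, a number 29 percentage points lower from compound 2 to compound 3 (beyond the scatter), with wide uncertainty. Compound 3 is estimated at 35%, ranging from 5% to 70% in this assay.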

Compound 3, a percentage reported as inhibition, in the whole organism at one dose (the size of the read-out at that dose, not a potency): 0%
The estimate for compound 3 lay 35 percentage points above the measured number; measured number outside the range, below it.
By their numbers in this assay, from the lowest: compounds 1 and 3 (each within the scatter of the next); then compound 2.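

In this assay, a nitrogen on the aromatic carbon is not enough for an effect at this position: acetamido in place of dimethylamino gives a number 64 percentage points lower from compound 2 to compound 3 (beyond the scatter), and acetamido in place of chloro gives no change at the digits printed from compound 1 to compound 3 (within the scatter). Of the three groups at this place, only dimethylamino stands beyond the scatter of the others. Nothing measured here bears on the reason for this difference.

Going by these compounds, it remains open whether the primary amine, methylamino or diethylamino would keep the read-out of compound 2. A single dose also leaves open how strong the effect of compound 2 would be at other doses.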